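The source may report more compounds than this note shows. Statements on the series, on what has been measured and on what is new or still open speak of the compounds shown alone.

Measured compounds:
compound 1, `O=S(=O)(NCCCNCc1ccc(Cl)c(Cl)c1)c1cc(C(F)(F)F)cc(C(F)(F)F)c1`, giving 2500 nM in a functional assay on HPAC cells (Homo sapiens) for inhibition, read by MTT assay, with a stated time of 72 h; on this read-out higher numbers stand for weaker inhibition of growth and lower numbers for stronger inhibition of growth;
compound 2, `O=S(=O)(NCCCNCc1cccc(Cl)c1)c1cc(C(F)(F)F)cc(C(F)(F)F)c1`, giving 2700 nM in this assay.

Among the compounds with values here, only two compounds have been measured in this assay, and compound 2 stands at a number that cannot be told apart from that of compound 1: the one measured step, a 1.1-fold higher number from compound 1 to compound 2 (0.03 log units; within the scatter), comes from removing a chloro group from the ring at the end of the chain, and it changed nothing beyond the scatter.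

Compound 3, `COc1ccccc1CNCCCNS(=O)(=O)c1cc(C(F)(F)F)cc(C(F)(F)F)c1`, has not yet been measured. It differs from compound 2 in one place: 2-methoxyphenyl in place of 3-chlorophenyl on a saturated chain carbon bound to an amine nitrogen. Within the data shown here, no measured step swaps one ring substituent for another of a different kind at this position, so the only guide is that loss of a chloro group there left the number unchanged in a 1.1-fold higher number from compound 1 to compound 2 (0.03 log units; within the scatter). On that basis a step of no clear direction is expected, and the estimate for compound 3 is 3000 nM, with a range from 1000 nM to 9000 nM, which means an expected step of a 1.1-fold higher number from compound 2 to compound 3 (0.05 log units; within the scatter).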

Compound 3, concentration for 50% growth inhibition: 2400 nM
Beside the measured number, compound 3's estimate is 1.3-fold (0.10 log units) above it, and the stated range covers the measured number.
By their numbers in this assay, from the lowest: compounds 3, 1 and 2 (each within the scatter of the next).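

In this assay, the earlier step showed only what happens when a chloro group is lost, whereas this result swaps the ring's substituent for one of a different kind. Putting 2-methoxyphenyl in place of 3-chlorophenyl gives a 1.1-fold lower number from compound 2 to compound 3 (0.05 log units; within the scatter), and putting it in place of 3,4-dichlorophenyl gives a 1.0-fold lower number from compound 1 to compound 3 (0.02 log units; within the scatter), so neither change to the group on this saturated chain carbon bound to an amine nitrogen shows any effect beyond the scatter, and the three compounds cannot be told apart on this read-out. Nothing available accounts for this lack of difference, and the data cannot say whether these ring groups matter little here or whether their separate effects simply happen to cancel.

Still open, going by these compounds, is whether any change at this position can move the number beyond the scatter, as a carboxylic acid or an amine on the ring might, or a plain phenyl ring with no substituent at all. The compounds shown also say nothing about a longer chain in the core or about replacing either trifluoromethyl group.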